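A few compounds are considered here, and "the series" means these few. Any claim that something is new, unique, unknown or untested is made for them only; others in the source may bear on it.

Working notes on the series. The shared core appears in compound 1 `N#Cc1c(N)nc2nc(C3CCCCC3)ncc2c1N`, compound 2 `CC(C)Cc1ncc2c(N)c(C#N)c(N)nc2n1` and compound 3 `CC(C)(C)c1nc(CCCCCC#N)c2c(N)c(C#N)c(N)nc2n1`. In a physicochemical assay for solubility, in phosphate buffer, with a stated time of 18 h (on this read-out lower numbers stand for lower solubility and higher numbers for higher solubility), compound 1 gives 81000 nM, compound 2 gives 268000 nM and compound 3 gives 6000 nM. Compound 3 stands lowest of the three numbers, with compound 1 nearest and compound 2 furthest, both gaps beyond the scatter. Among the compounds with values here, the only single-change step measured so far is a 3.3-fold higher number from compound 1 to compound 2 (0.52 log units; beyond the scatter), a modest move between two alkyl groups.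

Compound 4 `CC(C)(C)c1nc(-c2ccc(C(=O)O)s2)c2c(N)c(C#N)c(N)nc2n1` has not been measured. It differs from compound 3 in one place: 5-carboxythiophen-2-yl in place of 5-cyanopentyl on an aromatic carbon.

Within the data shown here, the measured step between alkyl groups does not cover a change of this kind, where a chain carrying a nitrile gives way to an aromatic ring carrying a carboxylic acid; the series offers no precedent for a carboxylic acid, and nothing here speaks to a thiophene. With compound 3 sitting at 6000 nM, the low end of the series, the expectation for compound 4 is an upward step, a 6.7-fold higher number from compound 3 to compound 4 (0.82 log units; beyond the scatter), beyond the scatter, though the size is uncertain. Compound 4 is therefore estimated at 40000 nM, with a range from 8000 nM to 200000 nM.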

Compound 4, solubility: > 1000000 nM
Compound 4: no number, only a limit; the forecaster's own chance of this, stated with the estimate: 10%; middle value at least 25-fold (1.39 log units) away from the limit.
By their numbers in this assay, from the lowest: compound 3; then compound 1; then compound 2. At a limit, above all of these: compound 4.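

In this assay compound 4 gives > 1000000 nM, which is a limit of the assay and not a number. Within the data shown here, the aromatic carbon that carries 5-cyanopentyl in compound 3 now shows that a change in one place on the shared core can move this read-out much further than the only earlier step between two alkyl groups, a 3.3-fold higher number from compound 1 to compound 2 (0.52 log units; beyond the scatter): the new step is an at least 160-fold higher number from compound 3 to compound 4 (2.22 log units; beyond the scatter), and it is large. That step has a lower bound only, so its full size stays unknown: the limit of > 1000000 nM in this assay, at which 1 of the 4 values shown sits.

The change replaces a chain with a ring and a nitrile with a carboxylic acid at the same time, so the compounds shown do not separate the contribution of the thiophene from that of the carboxylic acid. As far as these compounds go, it remains open where an unsubstituted thiophene, a methyl ester of the same acid or a pentyl chain ending in a carboxylic acid would stand at this aromatic carbon, and whether the carboxylic acid would give a similar step with the alkyl groups of compound 1 or compound 2 on the core.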